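The source may hold more compounds than are shown below. What is called first, only, known or untested is meant among the compounds shown, and "the series" means these compounds.

Measured so far:
compound 1 `O=C(c1cc(Cl)ccc1-c1ncccn1)N1CC2(CC2)C[C@H]1CNc1cc(C(F)(F)F)ccn1` — 8.1
compound 2 `O=C(c1cc(Cl)ccc1-c1ncccn1)N1CC2(CC2)C[C@H]1CNc1ccc(C(F)(F)F)cn1` — 8.1
compound 3 `CS(=O)(=O)c1ccc(-c2ccccc2)c(C(=O)N2CC3(CC3)C[C@H]2CNc2ccc(C(F)(F)F)cn2)c1` — 6.7

In a functional assay on CHO cells for antagonist activity at Orexin/Hypocretin receptor type 1 (Homo sapiens), read by FLIPR and calcium flux (on this read-out higher numbers stand for higher potency (the scale is a negative logarithm) and lower numbers for lower potency), compound 1 gives 8.1, level with compound 2 at the digits shown and together the highest of the three numbers; compound 3 gives 6.7, far lower. Compound 4 `Cc1ccc(-c2ncccn2)c(C(=O)N2CC3(CC3)C[C@H]2CNc2cc(C(F)(F)F)ccn2)c1` differs from compound 1 by methyl in place of chloro on an aromatic carbon. Within the data shown here, the only one-place step measured, no change at the digits printed from compound 1 to compound 2 (within the scatter), concerns the amine substituent and not this aromatic carbon, so no measured step bears directly on the change at hand; compound 3 differs from compound 1 in several places at once, and its value alone says nothing of chloro against methyl. A change of this kind is therefore expected to give no step beyond the scatter in this assay, a number 0.10 log units lower from compound 1 to compound 4 (within the scatter). Compound 4 is expected at 8, between 7.4 and 8.6.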

Compound 4, negative logarithm of the antagonist equilibrium constant: 7.3
The estimate for compound 4 lay 0.70 log units above the measured number; measured number below the stated range.
By their numbers in this assay, from the lowest: compound 3; then compound 4; then compounds 1 and 2 (each within the scatter of the next).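

Among these compounds, the aromatic carbon para to the pyrimidin-2-yl group responds to its substituent: methyl in place of chloro gives a number 0.80 log units lower from compound 1 to compound 4 (beyond the scatter), whereas the one earlier single-place step, on the amine substituent, gave no change at the digits printed from compound 1 to compound 2 (within the scatter). Of these two groups, chloro gives the higher number at this carbon, with the rest of compound 1 unchanged. Nothing available accounts for the difference between chloro and methyl.

Going by these compounds, whether fluoro, methoxy or nitrile at this carbon would match chloro remains open. Also open, on these data alone, is whether the same step would appear with the 5-(trifluoromethyl)pyridin-2-yl group of compound 2.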